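The source may hold more compounds than are shown below. What is called first, only, known or untested is meant among the compounds shown, and "the series" means these compounds.

In a functional assay on U-251 cells (Homo sapiens) for inhibition, read by sulforhodamine B assay, with a stated time of 48 h, tested at 1 uM (a higher number here means a weaker effect of the compound at the concentration tested, a lower number a stronger effect), compound 2 `COc1cc(Cl)cc(-c2nn(-c3cccc(NC(=O)Nc4ccc(Cl)c(C(F)(F)F)c4)c3)cc2-c2ccncc2)c1` gives 43%, the lower of the two numbers recorded, while compound 1 `O=C(Nc1cccc(-n2cc(-c3ccncc3)c(-c3cc(O)cc(Cl)c3)n2)c1)Nc1ccc(Cl)c(C(F)(F)F)c1` gives 56%; the step of a number 13 percentage points lower from compound 1 to compound 2 (beyond the scatter) concerns only the methyl on the oxygen. Compound 3 `COc1cc(Cl)cc(-c2nn(-c3cccc(NC(=O)c4cccc(C(F)(F)F)c4)c3)cc2-c2ccncc2)c1` differs from compound 2 in a different place: 3-(trifluoromethyl)phenyl in place of (4-chloro-3-(trifluoromethyl)phenyl)amino on a carbonyl carbon. No measured step touches the part where this change sits, so nothing shown tells how large the step will be or in which direction. Compound 3 is therefore expected to land near compound 2, with the step of a number 12 percentage points higher from compound 2 to compound 3 (beyond the scatter) only an estimate, at about 55%, within the range 30% to 85%.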

Compound 3, a percentage reported as activity, at one concentration (the size of the read-out at that concentration, not a potency): 65%
Estimate against measurement, compound 3: 10 percentage points below; low and high end bracket the measured number.
By their numbers in this assay, from the lowest: compound 2; then compounds 1 and 3 (each within the scatter of the next).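

In this assay the group on the carbonyl carbon matters: 3-(trifluoromethyl)phenyl in place of (4-chloro-3-(trifluoromethyl)phenyl)amino gives a number 22 percentage points higher from compound 2 to compound 3 (beyond the scatter), which means a weaker effect at the concentration tested. Going by these compounds alone, this is the first reading on that part of the molecule, as the earlier step concerned only the methyl on the oxygen. The change removes a chlorine and the amino hydrogen-bond donor together, and no measurement at hand explains the weaker effect.

Which of these two losses counts stays open. Also open, from the compounds shown here alone, is how a (3-(trifluoromethyl)phenyl)amino group or a 4-chloro-3-(trifluoromethyl)phenyl group on the same carbonyl carbon would compare.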